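Working notes: side-chain change from compound 1 to compound 4

The source may hold more compounds than are shown below. What is called first, only, known or untested is meant among the compounds shown, and "the series" means these compounds.

Among the measured compounds shown here, in a functional assay on SH-SY5Y cells (Homo sapiens) for cytotoxicity, read by MTT assay, with a stated time of 72 h (on this read-out lower numbers stand for stronger inhibition and higher numbers for weaker inhibition), compound 1 `CCC[S+]([O-])CCCCN=C=S` gives 7660 nM, the highest of the three numbers so far. Compound 2 `[O-][S+](CCCCN=C=S)Cc1ccccc1`, at 5210 nM, stays within the scatter of compound 1, and only compound 3 `COc1ccc(C[S+]([O-])CCCCN=C=S)cc1`, at 2790 nM, lies beyond it.

Compound 4 `[O-][S+](CCCCN=C=S)Cc1ccco1` is still unmeasured. Its difference from compound 1 is furan-2-yl in place of ethyl on a saturated chain carbon bound to a sulfur. For the measured compounds named here, no measured compound carries furan-2-yl. Going by the values given here, the one measured step, a 1.9-fold lower number from compound 2 to compound 3 (0.27 log units; within the scatter), is methoxy in place of hydrogen on an aromatic carbon, stays within the scatter and bears on the change only indirectly. Compound 2 and compound 3 do carry an aromatic ring on that chain carbon, so a small move to a lower number is expected in this assay, probably not beyond the scatter. The expected step is a 1.7-fold lower number from compound 1 to compound 4 (0.23 log units; within the scatter). For compound 4 the estimated value is 4500 nM, with an expected range of 2400 nM to 8400 nM.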

Compound 4, half-maximal inhibitory concentration: 7790 nM
Compound 4: middle estimate off by 1.7-fold (0.24 log units), on the low side; the measured number falls inside the stated range.
By their numbers in this assay, from the lowest: compounds 3, 2, 1 and 4 (each within the scatter of the next, the first and the last beyond it).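

In this assay, furan-2-yl in place of ethyl on a saturated chain carbon bound to a sulfur gives a 1.0-fold higher number from compound 1 to compound 4 (0.01 log units; within the scatter), so this position takes the larger five-membered aromatic ring with no readable shift in the number. Having an aromatic ring on this chain carbon is therefore not enough to move the number, at least where that ring is furan-2-yl. The data on hand offer nothing that accounts for this result.

The compounds shown leave open whether an amine, a carboxylic acid or a longer chain on this chain carbon would separate from compound 1. As far as these compounds go, it also remains open whether a methoxy group on the furan-2-yl ring would change the number in compound 4.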